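Placing a 1H-indol-1-yl Group on a Weak Compound

A few compounds are considered here, and "the series" means these few. Any claim that something is new, unique, unknown or untested is made for them only; others in the source may bear on it.

So far, three compounds built on one shared core have been tested in a functional assay on HepG2 cells (Homo sapiens) for antiproliferative activity, read by MTT assay, with a stated time of 48 h; a higher number here means a weaker inhibitor, a lower number a stronger inhibitor. Compound 1 `COc1ccc(CN(C(=O)Cn2cc(COc3ccc4c(C)cc(=O)oc4c3)nn2)c2cc(OC)c(OC)c(OC)c2)cc1` gives 1740 nM. Compound 2 `COc1ccc(CN(C(=O)Cn2cc(CSC3=NCCS3)nn2)c2cc(OC)c(OC)c(OC)c2)cc1` gives 25000 nM, and compound 3 `COc1ccc(CN(C(=O)Cn2cc(CSc3nnc(-c4ccccc4)c(-c4ccccc4)n3)nn2)c2cc(OC)c(OC)c(OC)c2)cc1` gives 21800 nM. Compound 2 therefore sits at the weak end of this small set, level with compound 3 within the usual scatter and well above compound 1.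

Compound 4 `COc1ccc(CN(C(=O)Cn2cc(Cn3ccc4ccccc43)nn2)c2cc(OC)c(OC)c(OC)c2)cc1` has not yet been measured. Compared with compound 2, it carries a group of 9 heavy atoms (8 carbon, 1 nitrogen; one five-membered aromatic ring with 1 hetero atom, one six-membered aromatic ring of carbon only) in place of a group of 6 heavy atoms (3 carbon, 1 nitrogen, 2 sulfur; one five-membered non-aromatic ring with 2 hetero atoms), on a saturated chain carbon bound to an aromatic carbon.

Among the measured compounds shown here, no measured pair shows this exact swap, so the guidance is thin. Compound 1 at 1740 nM suggests that the group at this place can matter a good deal. Compound 3 at 21800 nM goes against any simple rule that a bigger group gives a lower number. A moderate fall in the number, beyond the scatter but with real uncertainty, is expected: a 3.1-fold lower number from compound 2 to compound 4 (0.49 log units; beyond the scatter). For compound 4 the estimate is 8000 nM, with an expected range of 1800 nM to 28000 nM.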

Compound 4, half-maximal inhibitory concentration: 40100 nM
Beside the measured number, compound 4's estimate is 5.0-fold (0.70 log units) below it; measured number outside the range, above it.
By their numbers in this assay, from the lowest: compound 1; then compounds 3, 2 and 4 (each within the scatter of the next).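

In this assay, the 1H-indol-1-yl group in place of the group with two sulfur atoms gives a 1.6-fold higher number from compound 2 to compound 4 (0.21 log units; within the scatter), so on this saturated chain carbon bound to an aromatic carbon the two groups cannot be told apart. A larger group with aromatic rings is therefore not enough to reach the level of compound 1 at 1740 nM in this assay. Compound 3 and compound 4 both carry aromatic rings at this place, yet each stays within the scatter of compound 2.

Going by these compounds, whether a simple amine or a carboxylic acid on this carbon would give a lower number remains open. Nothing available explains why the group in compound 1 stands apart from the other three.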